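The source may hold more compounds than are shown below. What is called first, only, known or untested is meant among the compounds shown, and "the series" means these compounds.

Measured in an in vitro ADME assay on microsomes (Rattus norvegicus) for metabolic stability; a higher number here means that the compound lasts longer, a lower number that the compound disappears faster:
- Compound 1 `CCc1nc(-c2ccc(Cl)cc2Cl)c(CC)nc1NC(COC)COC`: 0.0417 h
- Compound 2 `CCc1nc(-c2cnc(OC)nc2OC)c(CC)nc1NC(CC)CC`: < 0.0167 h
- Compound 3 `CCc1nc(NC(CC)CC)c(F)nc1-c1ccc(Cl)cc1Cl`: 0.35 h

Compound 1, at 0.0417 h, holds the lower of the two actual numbers in this assay. Compound 3 stands higher at 0.35 h, a gap beyond the usual scatter. For compound 2, < 0.0167 h is a limit of the assay and not a number.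

Compound 4 `CCCN(CC1CC1)c1nc(CC)c(-c2ccc(Cl)cc2Cl)nc1CC` keeps the core of compound 1 but carries (cyclopropylmethyl)(propyl)amino in place of (2-methoxy-1-(methoxymethyl)ethyl)amino on an aromatic carbon. Within the data shown here, the measured compounds differ from one another in more than one place, and no measured step isolates this change. Without such a step, the expectation in this assay is for no shift beyond the scatter. The estimated step is a 1.4-fold lower number from compound 1 to compound 4 (0.14 log units; within the scatter). In this assay the expected value for compound 4 is 0.03 h, with an estimated range of 0.015 h to 0.1 h.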

Compound 4, half-life: 0.07 h
The estimate for compound 4 lay 2.3-fold (0.37 log units) below the measured number; low and high end bracket the measured number.
By their numbers in this assay, from the lowest: compounds 1 and 4 (each within the scatter of the next); then compound 3. At a limit, below all of these: compound 2.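

This is the only step among the compounds shown that isolates a single place: in this assay, (cyclopropylmethyl)(propyl)amino in place of (2-methoxy-1-(methoxymethyl)ethyl)amino gives a 1.7-fold higher number from compound 1 to compound 4 (0.22 log units; within the scatter). At this position on the core of compound 1, the exchange therefore leaves the half-life within the scatter, although the entering group has no oxygen, no hydrogen-bond donor and a three-membered ring. Only compound 2 sits at a limit, which is not a number, so the step rests on actual numbers at both ends: the limit of < 0.0167 h in this assay, at which 1 of the 4 values shown sits.

Since the exchange alters all of these features at once, the step cannot assign any share of the outcome to any one of them. On these data alone, how a longer alkyl chain on the nitrogen or a carboxylic acid at this position would fare remains open.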